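From 4-chlorobenzyl to 4-methylphenyl on the amide nitrogen

This account rests on a few compounds, and the source may have more. Where it says the series, first, only, none or still open, it means among the compounds named here.

Compound 1 `Cc1ccc(CNC(=O)CCN(Cc2ccc(C(=O)NO)cc2)C(=O)c2ccc(N(C)C)cc2)cc1` gives 260 nM
Compound 2 `CN(C)c1ccc(C(=O)N(CCC(=O)NCc2ccc(Cl)cc2)Cc2ccc(C(=O)NO)cc2)cc1` gives 310 nM

In a functional assay on IMR-32 cells (Homo sapiens) for antiproliferative activity, with a stated time of 72 h (a higher number here means a weaker inhibitor, a lower number a stronger inhibitor), compound 2 gives 310 nM and lies within the scatter of compound 1 at 260 nM in this two-compound set, so the two cannot be ranked. Compound 3 `Cc1ccc(NC(=O)CCN(Cc2ccc(C(=O)NO)cc2)C(=O)c2ccc(N(C)C)cc2)cc1` has not yet been measured. It differs from compound 2 by 4-methylphenyl in place of 4-chlorobenzyl on an amide-type nitrogen and keeps the shared core. Within the data shown here, only one measured step bears on this change: a 1.2-fold higher number from compound 1 to compound 2 (0.08 log units; within the scatter) for chloro in place of methyl on an aromatic carbon, which stays within the scatter. That step covers only the exchange of methyl and chloro. Among the measured compounds shown here, the change from benzyl to phenyl has no measured counterpart, and the data give no direction for it. In this assay no step beyond the scatter is therefore expected, though with wide uncertainty. The expected step is a 1.0-fold lower number from compound 2 to compound 3 (0.01 log units; within the scatter) in this estimate. Compound 3 is estimated at 300 nM with an expected range from 120 nM to 750 nM for repeat measurements.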

Compound 3, half-maximal inhibitory concentration: 300 nM
Beside the measured number, compound 3's estimate shows no gap at the digits printed; low and high end bracket the measured number.
By their numbers in this assay, from the lowest: compounds 1, 3 and 2 (each within the scatter of the next).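

In this assay, among these compounds, the direct benzyl-to-phenyl comparison with the 4-methyl group kept in place gives a 1.2-fold higher number from compound 1 to compound 3 (0.06 log units; within the scatter), the first reading of the length of this link on the amide-type nitrogen. Among the compounds shown here, the exchange of 4-chlorobenzyl for 4-methylphenyl, which alters both the link and the ring substituent, gives a 1.0-fold lower number from compound 2 to compound 3 (0.01 log units; within the scatter), so neither the single change nor the combined one separates these compounds, and the three cannot be ranked at this position. No supporting measurement bears on why these values fall within the scatter of one another.

Open, as far as these compounds go, is whether the flat reading extends beyond aromatic carbon rings carrying methyl or chloro: an amine or a carboxylic acid on the ring, a longer chain such as 2-phenylethyl, or a 4-chlorophenyl group, which would complete the set of benzyl and phenyl partners, could each read differently. From the compounds shown here alone, the three compounds also share the 4-(dimethylamino)benzoyl group and the hydroxamic acid, so whether the same flatness holds with other groups in those places remains unknown.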